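The source may report more compounds than this note shows. Statements on the series, on what has been measured and on what is new or still open speak of the compounds shown alone.

Compounds measured so far:
compound 1 `O=C(OCc1ccccc1)N1CCN(C(=S)SCc2cn(Cc3ccccc3F)nn2)CC1`, in a functional assay on ECa-109 cells (Homo sapiens) for inhibition, read by MTT assay, with a stated time of 72 h (on this read-out higher numbers stand for weaker inhibition and lower numbers for stronger inhibition), compound 1 gives 27000 nM
compound 2 `S=C(SCc1cn(Cc2ccccc2Cl)nn1)N1CCNCC1`, in this assay compound 2 gives > 128000 nM

The value of compound 2 is a limit of this assay, not a number; compound 2 sits at the limit of > 128000 nM in this assay, at which 1 of the 2 values shown sits. Compound 3 `S=C(SCc1cn(Cc2ccc(Cl)c(Cl)c2)nn1)N1CCNCC1` differs from compound 2 by 3,4-dichlorophenyl in place of 2-chlorophenyl on a saturated chain carbon bound to an aromatic nitrogen. Among the measured compounds shown here, no step between measured compounds covers this change, so the expected step from compound 2 to compound 3 is a step that the limit leaves unreadable from compound 2 to compound 3, with no direction beyond the scatter. For compound 3 the estimated value is 150000 nM, in the range 40000 nM to 400000 nM, and another limit is thought likely.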

Compound 3, half-maximal inhibitory concentration: > 128000 nM
Compound 3: a limit, no number; the forecaster's own chance of this, stated with the estimate: 65%; the middle value does not contradict the limit.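

Compound 2 and compound 3 both give a limit rather than a number, so no step between them can be read: the limit of > 128000 nM in this assay, at which 2 of the 3 values shown sit.

The compounds shown leave open whether 3,4-dichlorophenyl in place of 2-chlorophenyl changes inhibition at all.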